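From Ethoxy to Butoxy: Expected Cytotoxicity of Compound 4

The compounds below may be only part of what the source reports. "The series", "measured", "known", "first", "only" and "open" are said of these compounds alone.

In a toxicity assay on MRC5 cells (Homo sapiens) for cytotoxicity, read by MTT assay, with a stated time of 72 h (a lower number here means that less compound is needed, a higher number that more compound is needed for the effect), compound 3 `CCOc1ccc(/C=N/NC(N)=S)c2ccccc12` gives > 200000 nM, which is a limit of the assay rather than a number. Compound 1 `Cc1ccc(/C=N/NC(N)=S)c2ccccc12` gives 37000 nM in this assay. Compound 2 `NC(=S)N/N=C/c1ccc(F)c2ccccc12` gives > 200000 nM, again a limit. Two of the three values sit at this limit (the limit of > 200000 nM in this assay, at which 2 of the 3 values shown sit). Compound 4 `CCCCOc1ccc(/C=N/NC(N)=S)c2ccccc12` differs from compound 3 by ethyl in place of hydrogen on a saturated chain carbon, two bonds along the chain from an oxygen on an aromatic ring. The measured steps that bear on this are an at least 5.4-fold higher number from compound 1 to compound 3 (0.73 log units; beyond the scatter) and an at least 5.4-fold higher number from compound 1 to compound 2 (0.73 log units; beyond the scatter), while a step that the two limits leave unreadable from compound 2 to compound 3. Because an at least 5.4-fold higher number from compound 1 to compound 3 (0.73 log units; beyond the scatter) already reached the limit (the limit of > 200000 nM in this assay, at which 2 of the 3 values shown sit), compound 4 is expected to sit at the limit too. The expected change is a number no higher from compound 3 to compound 4 (the limit leaves the size open), no movement beyond the scatter. Compound 4 is therefore estimated at 200000 nM, between 70000 nM and 500000 nM.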

Compound 4, half-maximal effective concentration: 41000 nM
The estimate for compound 4 lay 4.9-fold (0.69 log units) above the measured number; the whole stated range lies above it.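

In this assay, going from ethoxy to butoxy gives an at least 4.8-fold lower number from compound 3 to compound 4 (0.68 log units; beyond the scatter), so lengthening this chain does not keep the number at the limit. Butoxy in place of fluoro gives an at least 4.8-fold lower number from compound 2 to compound 4 (0.68 log units; beyond the scatter), and butoxy in place of methyl gives a 1.1-fold higher number from compound 1 to compound 4 (0.04 log units; within the scatter). The limit therefore belongs to compound 2 and compound 3, not to every group at this position: the limit of > 200000 nM in this assay, at which 2 of the 4 values shown sit.

The compounds shown leave open whether a longer chain, such as hexyloxy, would lower the number further. They also leave open how an amine at this position would read.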